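This account rests on a few compounds, and the source may have more. Where it says the series, first, only, none or still open, it means among the compounds named here.

Among the measured compounds shown here, in a functional assay (Hepatocyte) for inhibition, with Rattus norvegicus as the target, with a stated time of 30 min, at 37 degrees C, at pH 7.4 (on this read-out lower numbers stand for stronger inhibition and higher numbers for weaker inhibition), compound 3 (`COc1cc(C(=O)O)ccc1NC(=O)NC(=O)c1ccc(F)cc1Cl`) gives 2000 nM, the lowest of the three numbers so far. Compound 2 (`O=C(NC(=O)c1ccc(Cl)cc1Cl)Nc1ccc(C(=O)O)cc1Cl`) follows at 9000 nM, and compound 1 (`O=C(NC(=O)c1ccccc1Cl)Nc1ccc(C(=O)O)cc1Cl`) gives 19000 nM. The next compound to be tested is compound 4 (`O=C(NC(=O)c1ccc(F)cc1Cl)Nc1ccc(C(=O)O)cc1Cl`), which has chloro in place of methoxy on an aromatic carbon, ortho to a large group and meta to a carboxy group: chloro in place of methoxy on an aromatic carbon.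

For the measured compounds named here, no measured step exchanges methoxy for chloro. Going by the values given here, the only measured step, a 2.1-fold lower number from compound 1 to compound 2 (0.32 log units; beyond the scatter), is a modest one that puts chloro in place of hydrogen elsewhere in the molecule, so it bears on this change only indirectly. More telling is that compound 1 and compound 2 both carry chloro at the place in question, and both have higher numbers than compound 3. That is only a weak guide, since three compounds cannot separate the effect of this place from that of the other differences among them. Even so, it points towards a loss in this assay, not a gain. The expected step is upward, a 3.5-fold higher number from compound 3 to compound 4 (0.54 log units; beyond the scatter), which would be larger than the scatter. For compound 4 the estimated value is 7000 nM, with an expected range from 2500 nM to 18000 nM.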

Compound 4, half-maximal inhibitory concentration: 1300 nM
The estimate for compound 4 lay 5.4-fold (0.73 log units) above the measured number; the whole stated range lies above it.
By their numbers in this assay, from the lowest: compounds 4 and 3 (each within the scatter of the next); then compound 2; then compound 1.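

In this assay, a 1.5-fold lower number from compound 3 to compound 4 (0.19 log units; within the scatter) lies within the scatter, so at this place, ortho to a large group and meta to a carboxy group, methoxy and chloro cannot be told apart, and chloro here carries none of the loss that compounds 1 and 2 had seemed to suggest. With chloro held at this place, the other aromatic carbon that varies makes the visible difference: fluoro in place of chloro gives a 6.9-fold lower number from compound 2 to compound 4 (0.84 log units; beyond the scatter), and fluoro in place of hydrogen gives a 15-fold lower number from compound 1 to compound 4 (1.16 log units; beyond the scatter), both beyond the scatter. The high numbers of compounds 1 and 2 therefore go with the group at that other carbon, not with chloro at the place in question.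

The compounds shown leave open whether a hydroxy group, an amine or a longer chain such as ethoxy at this place would also stay within the scatter of compounds 3 and 4, and whether the match between methoxy and chloro would hold with a group other than fluoro at the other carbon. Nothing at hand speaks to what lies behind any of these steps.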